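The source may report more compounds than this note shows. Statements on the series, on what has been measured and on what is new or still open speak of the compounds shown alone.

Series notes. The shared core of compound 1 `CN(C)CCn1cnnc1-c1cc(Oc2ccc(NC(=O)N/N=C/c3cccc(O)c3)cc2F)ccn1` carries a 3-hydroxyphenyl on a carbon with a double bond to nitrogen; in a functional assay on MKN-45 cells (Homo sapiens) for cytotoxicity, read by MTT assay, with a stated time of 72 h (on this read-out lower numbers stand for stronger inhibition and higher numbers for weaker inhibition), compound 1 gives 1370 nM. Compound 2 `CN(C)CCn1cnnc1-c1cc(Oc2ccc(NC(=O)N/N=C/c3ccc(F)cc3)cc2F)ccn1` has a 4-fluorophenyl at that carbon and gives 1030 nM. For the measured compounds named here, of the two numbers so far, compound 1 sits at the upper end, but the step of a 1.3-fold lower number from compound 1 to compound 2 (0.12 log units; within the scatter) lies within the scatter, so the two cannot be told apart.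

Compound 3 `CN(C)CCn1cnnc1-c1cc(Oc2ccc(NC(=O)N/N=C/c3c(Cl)cccc3Cl)cc2F)ccn1` differs from compound 1 as follows: 2,6-dichlorophenyl in place of 3-hydroxyphenyl on a carbon with a double bond to nitrogen. Going by the values given here, the only measured step that bears on this position is a 1.3-fold lower number from compound 1 to compound 2 (0.12 log units; within the scatter), where exchanging the aryl group gave no change beyond the scatter. Among the compounds with values here, no step for a 2,6-dichlorophenyl exists. Compound 3 is therefore expected to give 1100 nM (range 400 nM to 3000 nM), an estimated step of a 1.2-fold lower number from compound 1 to compound 3 (0.10 log units; within the scatter), within the scatter.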

Compound 3, half-maximal inhibitory concentration: 160 nM
Estimate against measurement, compound 3: 6.9-fold (0.84 log units) above, outside the stated range (below it).
By their numbers in this assay, from the lowest: compound 3; then compounds 2 and 1 (each within the scatter of the next).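

The position on the carbon with a double bond to nitrogen now proves sensitive to the aryl group: in this assay, 2,6-dichlorophenyl gives an 8.6-fold lower number from compound 1 to compound 3 (0.93 log units; beyond the scatter) and a 6.4-fold lower number from compound 2 to compound 3 (0.81 log units; beyond the scatter), whereas the earlier exchange of aryl groups gave only a 1.3-fold lower number from compound 1 to compound 2 (0.12 log units; within the scatter). Because both steps lie beyond the scatter, compound 3 is the most potent of the three, and the gain appears against either of the two earlier aryl groups rather than against 3-hydroxyphenyl alone. Nothing available explains why this group stands apart from the other two.

From the compounds shown here alone, it remains open whether both chlorines are needed, or whether a phenyl with one chlorine, or with methyl or bromine in place of the chlorines, would give a similar number. Also open, going by these compounds, is whether a cyclohexyl could replace the aromatic ring at this position.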